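This account rests on a few compounds, and the source may have more. Where it says the series, first, only, none or still open, it means among the compounds named here.

Three compounds have been examined for their ability to switch on the enzyme, measured in an assay on isolated protein for activation of Nicotinamide phosphoribosyltransferase (Homo sapiens); on this read-out lower numbers stand for an effect already at smaller amounts and higher numbers for an effect only at larger amounts of compound. Compound 1, with the structure `CCOC(=O)c1ccc(NC(=O)NCc2cocn2)cc1`, gives 27600 nM in this assay. Compound 2, with the structure `CCOC(=O)c1ccc(N/C(=N\C#N)NCc2ccncc2)cc1`, gives 41400 nM. Compound 3, with the structure `O=C(NCc1ccncc1)Nc1ccc(S(=O)(=O)c2cccc(Cl)c2)cc1`, gives 69 nM and so stands clearly apart from the other two, with the lowest number of the three; its nearest neighbour is compound 1, and compound 2 lies furthest from it, both gaps well beyond the usual scatter.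

Compound 4, with the structure `O=C(NCc1ccncc1)Nc1ccc(S(=O)(=O)c2ccc(Cl)cc2)cc1`, has not yet been measured. It differs from compound 3 in one place: 4-chlorophenyl in place of 3-chlorophenyl on a sulfonyl sulfur. The two structures hold the same atoms, joined differently, and the chlorophenyl still sits on the sulfonyl sulfur. For the measured compounds named here, no measured pair shows what a change of this kind does here, so there is no guide beyond compound 3 itself. With the same atoms arranged on the same framework, the step of a 1.3-fold higher number from compound 3 to compound 4 (0.12 log units; within the scatter) is expected to stay within the scatter or to weaken the effect only slightly. Compound 4 is therefore estimated at 90 nM, most likely between 25 nM and 320 nM.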

Compound 4, half-maximal effective concentration: 126 nM
Compound 4: the middle estimate sits 1.4-fold (0.15 log units) below what was measured; the measured number falls inside the stated range.
By their numbers in this assay, from the lowest: compounds 3 and 4 (each within the scatter of the next); then compounds 1 and 2 (each within the scatter of the next).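

In this assay, the change to 4-chlorophenyl in place of 3-chlorophenyl on a sulfonyl sulfur gives a 1.8-fold higher number from compound 3 to compound 4 (0.26 log units; within the scatter). This is the first pair shown that differs in only one place, and it indicates that the read-out does not separate these two chlorophenyl groups, so both arrangements of the same atoms fit the activity seen here. Nothing available explains this result.

The compounds shown leave open whether the chlorine itself matters, as neither a plain phenyl group nor a phenyl carrying fluorine or a methoxy group appears among them. They also do not show what a cyclohexyl group or a short alkyl chain would do on the sulfonyl sulfur in place of the aromatic ring.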